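Swapping the indole of a cyclic pentapeptide for a phenol

The source may hold more compounds than are shown below. What is called first, only, known or untested is meant among the compounds shown, and "the series" means these compounds.

Three cyclic peptides have been measured in a functional assay on BXPC-3 cells (Homo sapiens) for inhibition, tested at 5 uM; on this read-out lower numbers stand for less inhibition and higher numbers for more inhibition at the one concentration tested (going by the name of the read-out). Compound 1 `CC(C)C[C@@H]1NC(=O)[C@H](CC(C)C)NC(=O)[C@H](CC(C)C)NC(=O)[C@@H](Cc2c[nH]c3ccccc23)NC(=O)[C@H](CC(C)C)NC1=O` gives 30% there, the highest of the three numbers. Compound 3 `CC(C)C[C@@H]1NC(=O)[C@H](CC(C)C)NC(=O)[C@H](Cc2ccccc2)NC(=O)[C@@H](CO)NC(=O)[C@H](CC(C)C)NC1=O` gives 25% in this assay, which lies within the usual scatter of the number for compound 1. Compound 2 `CC[C@H]1NC(=O)[C@H](CC(C)C)NC(=O)[C@H](CC(C)C)NC(=O)[C@H](Cc2ccccc2)NC(=O)[C@H](CC(C)C)NC1=O` gives 17% in this assay, a number beyond the scatter below compound 1. Compounds 2 and 3 each differ from compound 1 in more than one place. Their numbers say only where they stand, not what any single change does.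

Compound 4 `CC(C)C[C@@H]1NC(=O)[C@H](CC(C)C)NC(=O)[C@H](CC(C)C)NC(=O)[C@@H](Cc2ccc(O)cc2)NC(=O)[C@H](CC(C)C)NC1=O` has not yet been measured. It differs from compound 1 in one place: 4-hydroxyphenyl in place of 1H-indol-3-yl on a saturated chain carbon bound to a saturated ring carbon.

Going by the values given here, no single-change step between measured compounds is available, so the expectation rests on the spread of the three numbers. The step from compound 1 to compound 4 in this assay is expected to be a modest drop, a number 8 percentage points lower from compound 1 to compound 4 (within the scatter), most likely within the scatter. Compound 4 is therefore estimated at 22%, with a range from 8% to 38%.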

Compound 4, a percentage reported as inhibition, at one concentration (the size of the read-out at that concentration, not a potency): 33%
Beside the measured number, compound 4's estimate is 11 percentage points below it; the range from low to high includes it.
By their numbers in this assay, from the lowest: compounds 2, 3, 1 and 4 (each within the scatter of the next, the first and the last beyond it).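

In this assay, going by these compounds alone, putting 4-hydroxyphenyl in place of 1H-indol-3-yl on a saturated chain carbon bound to a saturated ring carbon gives a number 3 percentage points higher from compound 1 to compound 4 (within the scatter), the first step in this set in which only one place changes. At this place, then, the read-out does not separate the two groups, even though the five-membered aromatic ring leaves and an oxygen enters. Nothing measured here bears on what lies behind this result.

The compounds shown leave open whether an amine or a carboxylic acid in place of the hydroxyl on the same six-membered aromatic ring would also stay within the scatter of compound 1. They also leave open what single changes elsewhere on the shared core would do, since compound 2 and compound 3 each differ from compound 1 in more than one place.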